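Compound 3 to compound 4: methyl for methoxy

This account rests on a few compounds, and the source may have more. Where it says the series, first, only, none or still open, it means among the compounds named here.

In an ADME assay on liver (Mus musculus) for metabolic stability, read by LC-MS, using microsomes and NADPH (on this read-out lower numbers stand for a less stable compound and higher numbers for a more stable compound), compound 1 (`COc1cc(CN(CC(C)C)C(CC(=O)O)c2ccc3c(c2)CCO3)ccc1OCCN1C(=O)CCC1=O`) gives 100%, compound 2 (`COc1cc(CN(CC(C)C)C(CC(=O)O)c2ccc(Cl)c(Cl)c2)ccc1OCCN1C(=O)CCC1=O`) gives 49% and compound 3 (`COc1cc(CN(CC(C)C)C(CC(=O)O)c2ccc(Cl)c(F)c2)ccc1OCCN1C(=O)CCC1=O`) gives 57%. Compound 3 therefore lies within the scatter of compound 2 and well away from compound 1.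

Compound 4 (`Cc1cc(CN(CC(C)C)C(CC(=O)O)c2ccc(Cl)c(F)c2)ccc1OCCN1C(=O)CCC1=O`) has methyl in place of methoxy on an aromatic carbon, ortho to a 2-(2,5-dioxopyrrolidin-1-yl)ethoxy group: methyl in place of methoxy on an aromatic carbon.

Within the data shown here, no measured step makes this change. All three alter the group on the saturated chain carbon bound to an amine nitrogen, so they bear on it only indirectly. The exchange of fluoro for chloro is small, with a number 8 percentage points higher from compound 2 to compound 3 (within the scatter), while the ring changes are large, with a number 51 percentage points lower from compound 1 to compound 2 (beyond the scatter) and a number 43 percentage points lower from compound 1 to compound 3 (beyond the scatter). Those large steps show how far this read-out can move within the series, so the range is kept wide.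

No step beyond the scatter is expected, and the estimate is a number 2 percentage points lower from compound 3 to compound 4 (within the scatter). For compound 4 the estimated value is 55%, with an expected range from 35% to 78%.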

Compound 4, percent of the compound remaining: 33%
Compound 4: middle estimate off by 22 percentage points, on the high side; measured number below the stated range.
By their numbers in this assay, from the lowest: compound 4; then compounds 2 and 3 (each within the scatter of the next); then compound 1.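

In this assay the position ortho to a 2-(2,5-dioxopyrrolidin-1-yl)ethoxy group proves responsive, with methyl in place of methoxy giving a number 24 percentage points lower from compound 3 to compound 4 (beyond the scatter) on an otherwise unchanged structure. The read-out therefore moves with a change on this aromatic ring as well as with the group on the saturated chain carbon, and the methoxy cannot be treated as interchangeable with methyl here. The exchange removes one oxygen and one hydrogen-bond acceptor, but no measurement available here explains the step.

From the compounds shown here alone, whether methyl gives a similar step alongside the group carried by compound 1 or compound 2 remains open. Also open, going by these compounds, is how ethoxy, hydroxyl, chloro or a nitrile at this position would read against methoxy and methyl.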